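A few compounds are considered here, and "the series" means these few. Any claim that something is new, unique, unknown or untested is made for them only; others in the source may bear on it.

Compound 1 `O=C(/C=C/c1ccc2c(c1)B(O)OC2)c1ccc(OCc2ccccc2)cc1`: in an ADME assay on L929 cells (Mus musculus) for cytotoxicity, read by resazurin assay, with a stated time of 72 h (a lower number here means a stronger inhibitor, a higher number a weaker inhibitor), compound 1 gives > 10 ug/mL, which is a limit of the assay.
Compound 2 `O=C(/C=C/c1ccc2c(c1)B(O)OC2)c1ccc(O)c(O)c1`: in this assay compound 2 gives > 10 ug/mL, again a limit.
Compound 3 `O=C(/C=C/c1ccc2c(c1)B(O)OC2)c1ccc(O)cc1`: in this assay compound 3 gives > 10 ug/mL, also a limit.

Within the data shown here, compound 3 thus stands at the limit of > 10 ug/mL in this assay, at which 3 of the 3 values shown sit; no compound has a numerical value. The steps a step that the two limits leave unreadable from compound 1 to compound 3 and a step that the two limits leave unreadable from compound 2 to compound 3 are therefore unreadable in size and direction.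

Compound 4 `Nc1cccc(C(=O)/C=C/c2ccc3c(c2)B(O)OC3)c1` is to be measured in this assay. The change is 3-aminophenyl in place of 4-hydroxyphenyl on a carbonyl carbon. No readable step bears on it, so no step beyond the scatter is expected in this assay. Compound 4 is expected at 15 ug/mL (range 7 ug/mL to 40 ug/mL), most likely again reported as a limit. The step that the limit leaves unreadable from compound 3 to compound 4 is the expected consequence.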

Compound 4, half-maximal inhibitory concentration: 10 ug/mL
Compound 4: the middle estimate sits 1.5-fold (0.18 log units) above what was measured, within the range that was stated.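

With 3-aminophenyl on the carbonyl carbon, the series gains its first actual number in this assay: compound 4 gives 10 ug/mL. This change yields a number no higher from compound 3 to compound 4 (the limit leaves the size open), so it shows direction at most, and its size cannot be read. Compound 1, compound 2 and compound 3 remain at a limit of the assay: the limit of > 10 ug/mL in this assay, at which 3 of the 4 values shown sit.

Going by these compounds, the true size of this step remains open. So does how a carboxylic acid or a dimethylamino group on the same aromatic ring would read in this assay.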